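Permeability step from compound 2 to compound 4

A few compounds are considered here, and "the series" means these few. Any claim that something is new, unique, unknown or untested is made for them only; others in the source may bear on it.

Measured compounds:
compound 1, `Cc1cccc([C@@H](O)C(=O)N2N=CC[C@H]2C(=O)NCc2cc(Cl)ccc2-n2cnnn2)c1`, 9.7 10^-6 cm/s
compound 2, `O=C(NCc1cc(Cl)ccc1-n1cnnn1)[C@@H]1[C@H]2C[C@H]2CN1C(=O)[C@H](O)c1ccccc1`, 12 10^-6 cm/s
compound 3, `O=C(NCc1cc(Cl)ccc1-n1cnnn1)[C@@H]1[C@@H]2C[C@@H]2CN1C(=O)[C@H](O)c1ccccc1`, 2.2 10^-6 cm/s

Three compounds of a shared core have been examined in an ADME assay on Caco-2 cells (Homo sapiens) for permeability, read by LC-MS, in the apical to basolateral direction, with a stated time of 60 min, at pH 6.5; a higher number here means that the compound crosses the layer faster, a lower number that the compound crosses the layer more slowly. Compound 2 stands highest of the three, with compound 1 nearest at a gap within the scatter and compound 3 furthest, with a change of a 5.5-fold lower number from compound 2 to compound 3 (0.74 log units; beyond the scatter). Among the compounds with values here, the only measured step therefore concerns configuration alone, because of the fact that compounds 2 and 3 differ only in the configuration as drawn, and it gives no guidance on an exchange of groups.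

Compound 4, `O=C(NCc1cc(Cl)ccc1-n1cnnn1)[C@@H]1[C@H]2C[C@H]2CN1C(=O)[C@H](O)Cn1cccn1`, has not been measured. It departs from compound 2 in one place: (1H-pyrazol-1-yl)methyl in place of phenyl on a saturated chain carbon bound to a carbonyl carbon and an oxygen on a saturated carbon.

Within the data shown here, none of the measured steps bears on this exchange; the data hold no case in which a group on that saturated chain carbon is replaced. Among the measured compounds shown here, the expectation for compound 4 in this assay can rest only on the value of compound 2 and on the size of the one measured step, which shows that a single change can move the number beyond the scatter. Compound 4 is estimated to give 5 10^-6 cm/s, with a range from 2 10^-6 cm/s to 12 10^-6 cm/s, which means an expected step of a 2.4-fold lower number from compound 2 to compound 4 (0.38 log units; beyond the scatter).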

Compound 4, apparent permeability: 0.31 10^-6 cm/s
The estimate for compound 4 lay 16-fold (1.21 log units) above the measured number; measured number outside the range, below it.
By their numbers in this assay, from the lowest: compound 4; then compound 3; then compounds 1 and 2 (each within the scatter of the next).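

In this assay, within the data shown here, the exchange of phenyl for (1H-pyrazol-1-yl)methyl on a saturated chain carbon bound to a carbonyl carbon and an oxygen on a saturated carbon gives a 39-fold lower number from compound 2 to compound 4 (1.59 log units; beyond the scatter), the first measured change of group at this place. This step is larger than the one produced by configuration alone, a 5.5-fold lower number from compound 2 to compound 3 (0.74 log units; beyond the scatter), so this place is shown to be able to move the number strongly even though the leaving and the entering group both hold 6 heavy atoms and neither carries a net charge; what is counted as different is the ring, with 2 hydrogen-bond acceptors in the entering group and 0 in phenyl. The information at hand offers no explanation for the size of this step, as it speaks only to a difference in configuration.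

The compounds shown leave open whether the fall goes with the pyrazole ring or with the extra carbon that links it, a question that a benzyl group or a directly attached 1H-pyrazol-1-yl group at the same place would separate. Also open, on these data alone, is whether the same exchange would give a step of similar size on the core of compound 1 or in the configuration of compound 3.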